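Swapping a chloropropyl chain for a methoxyphenyl ring

The source may hold more compounds than are shown below. What is called first, only, known or untested is meant among the compounds shown, and "the series" means these compounds.

In a functional assay on HCT-116 cells (Homo sapiens) for antiproliferative activity, read by MTT assay, with a stated time of 72 h (on this read-out lower numbers stand for stronger inhibition and higher numbers for weaker inhibition), compound 3 `O=C1O[C@H]([C@@H](O)Cn2cc(CCCCl)nn2)C(OCc2ccccc2)=C1OCc1ccccc1` gives 36100 nM, the highest of the two plain numbers shown. Compound 1 `O=C1O[C@H]([C@@H](O)Cn2cc(CNS(=O)(=O)c3ccc(Cl)cc3)nn2)C(OCc2ccccc2)=C1OCc1ccccc1` gives 8380 nM, and a 4.3-fold higher number from compound 1 to compound 3 (0.63 log units; beyond the scatter). Compound 2 `Cc1ccc(-c2cn(C[C@H](O)[C@H]3OC(=O)C(OCc4ccccc4)=C3OCc3ccccc3)nn2)cc1` reaches only a limit of this assay, > 100000 nM. That limit is recorded as the limit of > 100000 nM in this assay, at which 1 of the 3 values shown sits. Compound 4 `COc1ccc(-c2cn(C[C@H](O)[C@H]3OC(=O)C(OCc4ccccc4)=C3OCc3ccccc3)nn2)cc1` is not yet measured; in it (4-methoxyphenyl in place of 3-chloropropyl on an aromatic carbon). Among the compounds with values here, the one measured step that bears on this runs the opposite way: an at least 2.7-fold lower number from compound 2 to compound 3 (0.44 log units; beyond the scatter), so putting an aromatic ring back at that carbon points toward a weaker result. For compound 4 a step of a 2.8-fold higher number from compound 3 to compound 4 (0.44 log units; beyond the scatter) is therefore expected, quite possibly ending at a limit again. Compound 4 is estimated at 100000 nM, within a range from 30000 nM to 300000 nM.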

Compound 4, half-maximal inhibitory concentration: > 100000 nM
Compound 4: a limit, no number; the forecaster's own chance of this, stated with the estimate: 60%; the middle value lies on the limit itself.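

Replacing 3-chloropropyl with 4-methoxyphenyl gives an at least 2.7-fold higher number from compound 3 to compound 4 (0.44 log units; beyond the scatter), and replacing (((4-chlorophenyl)sulfonyl)amino)methyl with the same ring gives an at least 11-fold higher number from compound 1 to compound 4 (1.07 log units; beyond the scatter). Compound 4 thus joins compound 2 at a limit rather than a number, so a methoxy on the phenyl ring ends at the same place as a methyl: the limit of > 100000 nM in this assay, at which 2 of the 4 values shown sit. The step between these two compounds cannot be read. Still open, as far as these compounds go, is whether an amine or a carboxylic acid on that phenyl ring, or a chain longer than 3-chloropropyl at this carbon, would give a plain number again.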